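Chloro for methoxy on a dihydropyrimidine carboxanilide series

A few compounds are considered here, and "the series" means these few. Any claim that something is new, unique, unknown or untested is made for them only; others in the source may bear on it.

Measured compounds and values:
compound 1, `COc1ccc(NC(=O)C2=C(C)NC(=S)NC2c2cn(-c3ccccc3)nc2-c2ccccc2)cc1`, 77300 nM
compound 2, `CC1=C(C(=O)Nc2ccc(Cl)cc2)C(c2cn(-c3ccccc3)nc2-c2ccccc2)NC(=S)N1`, 34700 nM
compound 3, `COc1ccc(NC(=O)C2=C(C)NC(=O)NC2c2cn(-c3ccccc3)nc2-c2ccc(Cl)cc2)cc1`, 69700 nM

Three compounds were tested in a functional assay on MCF7 cells (Homo sapiens) for inhibition, read by sulforhodamine B assay, with a stated time of 24 h; on this read-out lower numbers stand for stronger inhibition of growth and higher numbers for weaker inhibition of growth. Compound 1 gives 77300 nM, and compound 2 gives 34700 nM. The change between them is a single one: chloro in place of methoxy on an aromatic carbon. This change gave a 2.2-fold lower number from compound 1 to compound 2 (0.35 log units; beyond the scatter), a step that lies beyond the usual scatter. Compound 3 gives 69700 nM; its value sits within the scatter of compound 1 and within the scatter of compound 2, so no order among these pairs is claimed. The difference between the core of compound 3 and the core of compound 1 is not broken down here.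

Compound 4, `CC1=C(C(=O)Nc2ccc(Cl)cc2)C(c2cn(-c3ccccc3)nc2-c2ccc(Cl)cc2)NC(=O)N1`, has not yet been measured in this assay. It differs from compound 3 by chloro in place of methoxy on an aromatic carbon, the same kind of change as that from compound 1 to compound 2, at the same place. Going by the values given here, with only one prior instance of this change, the expectation rests on that step alone: from compound 3 to compound 4 a step of about a 2.2-fold lower number from compound 3 to compound 4 (0.34 log units; beyond the scatter) is expected, because a 2.2-fold lower number from compound 1 to compound 2 (0.35 log units; beyond the scatter). Compound 4 is therefore estimated at 32000 nM, with a likely range from 14000 nM to 72000 nM.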

Compound 4, concentration for 50% growth inhibition: 56900 nM
Beside the measured number, compound 4's estimate is 1.8-fold (0.25 log units) below it; the range from low to high includes it.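

In this assay, chloro in place of methoxy on the core of compound 3 gave a 1.2-fold lower number from compound 3 to compound 4 (0.09 log units; within the scatter), so no change can be claimed on this core. Set beside the earlier step on the core of compound 1, the new step does not differ from it by more than the scatter allows: the same change on two cores in this assay, a 2.2-fold lower number (0.35 log units; beyond the scatter) from compound 1 to compound 2 and a 1.2-fold lower number (0.09 log units; within the scatter) from compound 3 to compound 4, 1.8-fold (0.26 log units) apart, within the scatter of two such steps. Going by these compounds alone, the result is therefore compatible with the change carrying over from one core to the other, but it does not show that it does, as only one of the two steps lies beyond the scatter and two pairs cannot fix the size of the step on either core.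

The compounds shown leave open how other groups in this place, such as fluoro, nitrile or dimethylamino, would read against methoxy and chloro. They also leave open whether the step would hold on a core with an ester in place of the carboxamide.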